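Chloro for Fluoro on the Ring Bound to Nitrogen

This account rests on a few compounds, and the source may have more. Where it says the series, first, only, none or still open, it means among the compounds named here.

Compound 1 `Oc1cc(C(F)(F)F)ccc1-c1nc(-c2ccccc2O)n(-c2ccc(F)cc2)n1`: 86.7%
Compound 2 `Oc1cc(C(F)(F)F)ccc1-c1nc(-c2ccccc2O)n(-c2ccc(Cl)cc2)n1`: 87.3%
Compound 3 `Oc1cc(C(F)(F)F)ccc1-c1nc(-c2ccccc2O)n(-c2ccccc2F)n1`: 86.6%

Of the compounds shown here, three sharing one core have been measured in a functional assay on PC-12 cells (Rattus norvegicus) for cytotoxicity, read by MTT assay, with stated times of 2 h and 24 h, tested at 5 uM; on this read-out higher numbers stand for a stronger effect at the one concentration tested and lower numbers for a weaker effect. Compound 1 gives 86.7%, compound 2 gives 87.3% and compound 3 gives 86.6%. The steps among them, a number 0.6 percentage points higher from compound 1 to compound 2 (within the scatter), a number 0.1 percentage points lower from compound 1 to compound 3 (within the scatter) and a number 0.7 percentage points lower from compound 2 to compound 3 (within the scatter), all fall within the scatter, so none of the three can be set apart from the others.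

Compound 4 `Oc1cc(C(F)(F)F)ccc1-c1nc(-c2ccccc2O)n(-c2ccccc2Cl)n1` has not yet been measured in this assay. It arises from compound 3 by chloro in place of fluoro on an aromatic carbon. The same change, chloro in place of fluoro on an aromatic carbon, has already been made once, from compound 1 to compound 2: chloro in place of fluoro on an aromatic carbon, with the step of a number 0.6 percentage points higher from compound 1 to compound 2 (within the scatter). The two cores differ as follows: 2-fluorophenyl in place of 4-fluorophenyl on an aromatic nitrogen. The place of the change is not identical in the two pairs, being para to a large group in the first pair and ortho to a large group in the second, so this is the same kind of change rather than the same change.

Because the earlier step of a number 0.6 percentage points higher from compound 1 to compound 2 (within the scatter) stayed within the scatter, and because compound 3 itself gives 86.6%, the step for compound 4 is expected to be small, about a number 0.4 percentage points higher from compound 3 to compound 4 (within the scatter). Compound 4 is therefore estimated at 87% in this assay, with a likely range from 80% to 93%.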

Compound 4, a percentage reported as activity, at one concentration (the size of the read-out at that concentration, not a potency): 90.6%
Beside the measured number, compound 4's estimate is 3.6 percentage points below it; the measured number falls inside the stated range.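

Set side by side, the two steps for chloro in place of fluoro on an aromatic carbon in this assay do not differ: the same change on two cores in this assay, a number 0.6 percentage points higher (within the scatter) from compound 1 to compound 2 and a number 4 percentage points higher (within the scatter) from compound 3 to compound 4, 3.4 percentage points apart, within the scatter of two such steps

The new step, a number 4 percentage points higher from compound 3 to compound 4 (within the scatter), is joined by two others, a number 3.3 percentage points higher from compound 2 to compound 4 (within the scatter) and a number 3.9 percentage points higher from compound 1 to compound 4 (within the scatter), and with all of them inside the scatter the four compounds cannot be set apart on this read-out. Going by these compounds alone, the series therefore gives no sign that the shared change behaves differently on the two cores, but it rests on only two pairs of compounds at a single concentration, and since neither step exceeds the scatter, it does not show that the change has a real effect that carries from one core to the other.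

The compounds shown carry only fluoro or chloro on the ring bound to nitrogen, with the hydroxyl and trifluoromethyl groups of the shared core left in place throughout. From the compounds shown here alone, what bromo, methoxy or an amine on that ring would give remains open, as does whether steps beyond the scatter would appear at other concentrations.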